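Methyl in place of methoxy on a benzyl group

The source may report more compounds than this note shows. Statements on the series, on what has been measured and on what is new or still open speak of the compounds shown alone.

Measured in a functional assay on HCT-116 cells (Homo sapiens) for inhibition, read by MTT assay, with a stated time of 48 h; on this read-out lower numbers stand for stronger inhibition and higher numbers for weaker inhibition:
Compound 1 `COc1cc(-c2nnc(S)n2-c2ccc(N(C)C)cc2)cc(OC)c1OC`: > 60000 nM (a limit)
Compound 2 `COc1ccc(CSc2nnc(-c3cc(OC)c(OC)c(OC)c3)n2-c2ccc(N(C)C)cc2)cc1`: 1150 nM

For the measured compounds named here, compound 2 stands at 1150 nM, the only true number so far. Compound 1 reads > 60000 nM, which is a limit of the assay and not a number. With 4-methoxybenzyl in place of hydrogen on a sulfur, the measurements show an at least 52-fold lower number from compound 1 to compound 2 (1.71 log units; beyond the scatter), a large step.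

Compound 3 `COc1cc(-c2nnc(SCc3ccc(C)cc3)n2-c2ccc(N(C)C)cc2)cc(OC)c1OC` keeps the rest of compound 2 but carries methyl in place of methoxy on an aromatic carbon, para to a large group (methyl in place of methoxy on an aromatic carbon). Going by the values given here, no measured step changes this group alone. Among the compounds with values here, the single step of an at least 52-fold lower number from compound 1 to compound 2 (1.71 log units; beyond the scatter) adds the whole 4-methoxybenzyl group, whereas here only its methoxy is replaced, so that step sets no size for this change. In this assay a small shift is therefore expected, probably none beyond the scatter and with no firm direction.

For compound 3 the estimated value is 1300 nM, with an expected range from 450 nM to 3800 nM. This estimate means an expected 1.1-fold higher number from compound 2 to compound 3 (0.05 log units; within the scatter).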

Compound 3, half-maximal inhibitory concentration: > 60000 nM
Compound 3: no number, only a limit; the forecaster's own chance of this, stated with the estimate: 3%; middle value at least 46-fold (1.66 log units) from the limit.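

In this assay, the gain seen on the sulfur does not belong to a benzyl group as such, for this single exchange on the aromatic carbon para to a large group, methyl in place of methoxy, gives an at least 52-fold higher number from compound 2 to compound 3 (1.71 log units; beyond the scatter), a large step beyond the scatter. Among the compounds shown, the 4-methoxybenzyl group is thus the only sulfur substituent that brings a true number, and the 4-methylbenzyl group does not share it. The value of compound 3, > 60000 nM, is a limit of the assay and not a number, so the step gives only a lowest size, and the step from compound 1 to compound 3 cannot be read, since both ends are limits: the limit of > 60000 nM in this assay, at which 2 of the 3 values shown sit.

With only methoxy and methyl at this place, the compounds shown leave open whether a hydroxyl, an ethoxy or a fluorine there would read closer to compound 2 or to compound 3. They also leave open how an unsubstituted benzyl group or a dimethylamino group at the same place would read in this assay.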